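Branching the amide chain when every value is a limit

The source may report more compounds than this note shows. Statements on the series, on what has been measured and on what is new or still open speak of the compounds shown alone.

Compound 1 `C=CC1=C(C(=O)NCCC)C(c2ccc(Cl)c(Cl)c2)OC1`: in a functional assay on A549 cells (Homo sapiens) for cytotoxicity, read by MTT assay, with a stated time of 24 h (on this read-out lower numbers stand for stronger inhibition and higher numbers for weaker inhibition), compound 1 gives only a limit of the assay, > 100000 nM.
Compound 2 `C=CC1=C(C(=O)NCC(C)C)C(c2ccc(Cl)c(Cl)c2)OC1`: in this assay compound 2 gives only a limit of the assay, > 100000 nM.
Compound 3 `C=CC1=C(C(=O)NCCC)C(c2ccc(OC)cc2)OC1`: in this assay compound 3 gives only a limit of the assay, > 100000 nM.

Compound 1 and compound 2 share one core, and compound 3 shares a second core with the not yet measured compound 4 `C=CC1=C(C(=O)NCC(C)C)C(c2ccc(OC)cc2)OC1`. The difference between the two cores is not broken down here. Within the first pair the change is methyl in place of hydrogen on a saturated chain carbon bound to two saturated chain carbons. In this assay this reads as a step that the two limits leave unreadable from compound 1 to compound 2, because both values sit at the limit of > 100000 nM in this assay, at which 3 of the 3 values shown sit; a step between two limits has no readable size.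

Compound 4 differs from compound 3 by methyl in place of hydrogen on a saturated chain carbon bound to two saturated chain carbons, the same change, at the same place. Among the measured compounds shown here, the only guide to it is the earlier pair, which says nothing about direction or size because everything measured rests on (the limit of > 100000 nM in this assay, at which 3 of the 3 values shown sit). What can be said is that compound 3 is itself a limit, and that the same change on the other core did not bring either partner below that limit.

The step from compound 3 to compound 4 in this assay is therefore expected to be a step that the limit leaves unreadable from compound 3 to compound 4. Compound 4 is estimated at 150000 nM in this assay, most likely reported once more only as a limit. The expected range for compound 4 runs from 40000 nM to 500000 nM.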

Compound 4, half-maximal inhibitory concentration: > 100000 nM
Compound 4 ended at the assay's limit (the forecaster's own chance of this, stated with the estimate: 85%); the middle value does not contradict the limit.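

In this assay compound 4 gives only a limit, > 100000 nM. Compound 3 is a limit too, so no step can be read between compound 3 and compound 4, because every value rests on the same limit: the limit of > 100000 nM in this assay, at which 4 of the 4 values shown sit.

The compounds shown leave open whether methyl in place of hydrogen at this place changes cytotoxicity at all, and whether any of these compounds has a real value beyond that limit.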